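Replacing the acid chain on the indole nitrogen

This account rests on a few compounds, and the source may have more. Where it says the series, first, only, none or still open, it means among the compounds named here.

Compound 1 `COc1ccc(NC(=O)C(=O)c2cn(C(C)(C)COCC(=O)O)c3ccccc23)cn1` was tested in a functional assay on FaDu cells (Homo sapiens) for cytotoxicity, read by MTT assay, with a stated time of 72 h; on this read-out higher numbers stand for lower toxicity in this test and lower numbers for higher toxicity in this test. In this assay compound 1 reaches only the limit of the measurement, > 10000 nM, and no number is known for it. The evidence about it is therefore just that (the limit of > 10000 nM in this assay, at which 1 of the 2 values shown sits), which places compound 1 at the weak end of what the test can show. Among the compounds with values here, the other measured compound, compound 2 `COc1ccc(NC(=O)C(=O)c2cc(C(C)C)n3ccccc23)cn1`, is built on a different core, and in this assay compound 2 gives 160 nM; no single-point step links it to compound 1, so the two values are simply noted side by side.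

The unmeasured compound 3 `COc1ccc(NC(=O)C(=O)c2cn(CC3CCCO3)c3ccccc23)cn1` keeps the core of compound 1 and differs in one place: a group of 6 heavy atoms (5 carbon, 1 oxygen; one five-membered non-aromatic ring with 1 hetero atom) in place of a group of 9 heavy atoms (6 carbon, 3 oxygen; no ring), on an aromatic nitrogen. Since compound 1 is known only as a limit, the size of this step cannot be taken from a measured pair. It is expected that the change from compound 1 to compound 3 moves toward higher toxicity, as an at least 6.6-fold lower number from compound 1 to compound 3 (0.82 log units; beyond the scatter). Compound 3 is estimated at 1500 nM, with a range from 200 nM to 10000 nM.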

Compound 3, concentration lethal to 50% of the cells in the FaDu assay: 31 nM
Beside the measured number, compound 3's estimate is 48-fold (1.68 log units) above it, outside the stated range (below it).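

The result shows that this position, an aromatic nitrogen of the core of compound 1, is far from indifferent in the FaDu assay: putting (oxolan-2-yl)methyl in place of the open chain of 9 heavy atoms gives an at least 320-fold lower number from compound 1 to compound 3 (2.50 log units; beyond the scatter), a large change from a single point of difference. In a physicochemical assay for solubility, in phosphate buffer, at pH 7.4 (a lower number here means a less soluble compound, a higher number a more soluble compound), compound 3 gives 10000 nM, but the step to it from compound 1 cannot be read. In the physicochemical assay compound 1 gives <= 200000 nM and this is a limit of the test, not a number. In this test compound 1 is known only as a limit: the limit of <= 200000 nM in the physicochemical assay, at which 1 of the 2 values shown sits.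

Going by these compounds, what stays open is which part of the change carries the step in the FaDu assay, the loss of the open chain with its hydrogen-bond donor or the arrival of the five-membered non-aromatic ring. A plain butyl chain or an aminoethyl chain on the same nitrogen would help to separate these two parts, and would also show whether the values in the FaDu assay and the physicochemical assay move together at this position.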